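The source may report more compounds than this note shows. Statements on the series, on what has been measured and on what is new or still open speak of the compounds shown alone.

Compound 1 `CN1CCN(S(=O)(=O)c2ccc(Nc3nccc(Nc4ccc5nc[nH]c5c4)n3)cc2)CC1`: > 25000 nM (a limit)
Compound 2 `O=S(=O)(c1ccc(Nc2nccc(Nc3ccc4nc[nH]c4c3)n2)cc1)N1CCOCC1`: > 25000 nM (a limit)
Compound 3 `O=C1NC(Cc2ccc(Nc3nccc(Nc4ccc5cn[nH]c5c4)n3)cc2)CO1`: 20000 nM

For the measured compounds named here, in a functional assay on HepG2 cells (Homo sapiens) for inhibition, read by fluorescence and resazurin assay, with a stated time of 72 h (a lower number here means a stronger inhibitor, a higher number a weaker inhibitor), compound 3 gives 20000 nM, the only actual number among the three values. The other two are the limit of > 25000 nM in this assay, at which 2 of the 3 values shown sit. Compound 4 `O=C(Nc1ccc(Nc2nccc(Nc3ccc4cn[nH]c4c3)n2)cc1)Nc1cccc(F)c1` carries ((3-fluorophenyl)carbamoyl)amino in place of (2-oxo-1,3-oxazolidin-4-yl)methyl on an aromatic carbon. Going by the values given here, the sole measured step, a step that the two limits leave unreadable from compound 1 to compound 2, concerns a different exchange, on a sulfonyl sulfur, and offers no usable size. The expectation therefore rests on compound 3 at 20000 nM, which leaves little room toward weaker values. A moderate move toward stronger inhibition is expected, with an estimated 2.5-fold lower number from compound 3 to compound 4 (0.40 log units; beyond the scatter). The estimate for compound 4 is 8000 nM, with an expected range of 2000 nM to 25000 nM.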

Compound 4, half-maximal inhibitory concentration: 6600 nM
Estimate against measurement, compound 4: 1.2-fold (0.08 log units) above, and the stated range covers the measured number.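

In this assay, ((3-fluorophenyl)carbamoyl)amino in place of (2-oxo-1,3-oxazolidin-4-yl)methyl gives a 3.0-fold lower number from compound 3 to compound 4 (0.48 log units; beyond the scatter), so a change on this aromatic carbon moves the read-out measurably. This is the only step in the set with a readable size, since the step between compound 1 and compound 2 cannot be read: the limit of > 25000 nM in this assay, at which 2 of the 4 values shown sit.

The whole group changes at once, so the step cannot be assigned to the fluorine, the phenyl ring or the carbamoyl amino link. From the compounds shown here alone, whether a plain phenylcarbamoyl amino group or a carboxylic acid at this place would shift the number remains open.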